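Swapping a ring for dimethylamino on the shared core

This account rests on a few compounds, and the source may have more. Where it says the series, first, only, none or still open, it means among the compounds named here.

Compound 1 `Cc1nn(C)c(-n2cccc2)c1/C=N/OCc1ccc(C(=O)OC(C)(C)C)cc1` in a functional assay on SK-OV-3 cells (Homo sapiens) for cytotoxicity (a higher number here means a weaker inhibitor, a lower number a stronger inhibitor), gives 3.91 ug/mL
Compound 2 `Cc1nn(C)c(-n2cccn2)c1/C=N/OCc1ccc(C(=O)OC(C)(C)C)cc1` in this assay gives 9.63 ug/mL

Compound 2 holds the higher of these two numbers, which makes it the weaker inhibitor of the pair. Compound 3 `Cc1nn(C)c(N(C)C)c1/C=N/OCc1ccc(C(=O)OC(C)(C)C)cc1` carries dimethylamino in place of 1H-pyrazol-1-yl on an aromatic carbon and is otherwise unchanged. Within the data shown here, only one measured step bears on this change: a 2.5-fold higher number from compound 1 to compound 2 (0.39 log units; beyond the scatter) when 1H-pyrazol-1-yl replaced 1H-pyrrol-1-yl at the same place. That modest step exchanged one ring for another, whereas dimethylamino has no ring, so the guidance is indirect. In this assay a small step is expected, leaning towards a lower number since compound 2 sits at the top of the pair. The estimated step is a 1.4-fold lower number from compound 2 to compound 3 (0.14 log units; within the scatter) and may not exceed the scatter. For compound 3 the expected value is 7 ug/mL with an estimated range from 2.5 ug/mL to 20 ug/mL as the likely span.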

Compound 3, half-maximal inhibitory concentration: 9.06 ug/mL
For compound 3 the middle estimate is 1.3-fold (0.11 log units) below the measured one; the range from low to high includes it.
By their numbers in this assay, from the lowest: compound 1; then compounds 3 and 2 (each within the scatter of the next).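

In this assay, replacing 1H-pyrazol-1-yl with dimethylamino, which has no ring, gives a 1.1-fold lower number from compound 2 to compound 3 (0.03 log units; within the scatter), so a ring at this position is not needed to match compound 2. Set against 1H-pyrrol-1-yl, the same group gives a 2.3-fold higher number from compound 1 to compound 3 (0.36 log units; beyond the scatter), which leaves compound 1 as the strongest inhibitor of the three, with only this one ring giving the lower number. No measurement here accounts for why 1H-pyrrol-1-yl stands apart.

On these data alone, what a cyclic amine such as piperidine or a plain chain such as n-butyl would do at this place stays open. As far as these compounds go, it is also open whether the lower number of compound 1 belongs to 1H-pyrrol-1-yl alone or would also appear with another ring, such as phenyl.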